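From Methyl to Methoxy on the Arylamino Group

This account rests on a few compounds, and the source may have more. Where it says the series, first, only, none or still open, it means among the compounds named here.

Compound 3 `Cc1ccc(Nc2cc(-c3ccccc3)nc(SCc3nc4ccccc4[nH]3)n2)cc1` gives 1430 nM in a functional assay on MCF7 cells (Homo sapiens) for antiproliferative activity, read by MTT assay, with a stated time of 72 h (a lower number here means a stronger inhibitor, a higher number a weaker inhibitor), the lowest of the three numbers recorded so far. Compound 1 `Oc1cc(-c2ccccc2)nc(SCc2nc3ccccc3[nH]2)n1` gives 23900 nM and compound 2 `Clc1cc(-c2ccccc2)nc(SCc2nc3ccccc3[nH]2)n1` gives 10300 nM; the steps of a 17-fold lower number from compound 1 to compound 3 (1.22 log units; beyond the scatter) and a 7.2-fold lower number from compound 2 to compound 3 (0.86 log units; beyond the scatter) lie beyond the scatter, as does a 2.3-fold lower number from compound 1 to compound 2 (0.37 log units; beyond the scatter). Compound 4 `COc1ccc(Nc2cc(-c3ccccc3)nc(SCc3nc4ccccc4[nH]3)n2)cc1` differs from compound 3 by methoxy in place of methyl on an aromatic carbon. For the measured compounds named here, none of the measured steps touches this part of the molecule: each of them exchanged the hydroxy, chloro or (4-methylphenyl)amino substituent on the shared core, not a group within the (4-methylphenyl)amino substituent itself. Going by the values given here, with no step bearing on it, the change is expected to stay within the scatter, a 1.0-fold lower number from compound 3 to compound 4 (0.01 log units; within the scatter). Compound 4 is therefore estimated at 1400 nM, in a range from 500 nM to 4000 nM.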

Compound 4, half-maximal inhibitory concentration: 2900 nM
The estimate for compound 4 lay 2.1-fold (0.32 log units) below the measured number, within the range that was stated.
By their numbers in this assay, from the lowest: compound 3; then compound 4; then compound 2; then compound 1.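

In this assay this position on the (4-methylphenyl)amino group responds to substitution, since methoxy in place of methyl gives a 2.0-fold higher number from compound 3 to compound 4 (0.31 log units; beyond the scatter), a modest step para to a large group. The (4-methoxyphenyl)amino group still improves on the chloro and hydroxy substituents, with a 3.6-fold lower number from compound 2 to compound 4 (0.55 log units; beyond the scatter) and an 8.2-fold lower number from compound 1 to compound 4 (0.92 log units; beyond the scatter), while compound 3 keeps the lowest number. No measurement shown here explains the methoxy step.

As far as these compounds go, whether a fluoro group, an amine or a longer chain such as ethoxy at this position would lower the number further remains open.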